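This account rests on a few compounds, and the source may have more. Where it says the series, first, only, none or still open, it means among the compounds named here.

Measured so far:
- compound 1, `CC(=O)SCCOP(=O)(OCCSC(C)=O)OC[C@H]1CC[C@@H](n2cnc3c(N)ncnc32)O1`: 13000 nM
- compound 2, `CC(=O)SCCOP(=O)(OCCSC(C)=O)OC[C@H]1C=C[C@@H](n2cc(F)c(N)nc2=O)O1`: 52000 nM

Both compounds were tested in a functional assay on CCRF-CEM cells (Homo sapiens) for cytotoxicity; a lower number here means a stronger inhibitor, a higher number a weaker inhibitor. Of the two numbers, compound 2 carries the higher one, so it is the weaker of the pair; the gap to compound 1, which sits lower, lies beyond the usual scatter of this kind of measurement. The two differ in several places at once, so nothing can be said about any single part of that gap.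

Compound 3, `CC(=O)SCCOP(=O)(OCCS)OC[C@H]1C=C[C@@H](n2cc(F)c(N)nc2=O)O1`, is not yet measured. It differs from compound 2 in one place only: hydrogen in place of acetyl on a sulfur. The rest of the molecule, including the shared core and the second acetylsulfanyl chain, is unchanged.

For the measured compounds named here, no pair of measured compounds shows what this change does on its own, so the expectation rests on the single step alone. Since only one of two matching chains loses its acetyl, a small step is expected, one that may well stay within the scatter; the step from compound 2 to compound 3 is estimated at a 1.1-fold higher number from compound 2 to compound 3 (0.02 log units; within the scatter). Compound 3 is therefore expected to come out near 55000 nM in this assay, with a likely range from 18000 nM to 160000 nM.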

Compound 3, half-maximal inhibitory concentration: 52000 nM
For compound 3 the middle estimate is 1.1-fold (0.02 log units) above the measured one, within the range that was stated.
By their numbers in this assay, from the lowest: compound 1; then compounds 2 and 3 (each within the scatter of the next).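

For the compounds shown here, putting hydrogen in place of acetyl on a sulfur gives no change at the digits printed from compound 2 to compound 3 (within the scatter) in this assay and is the first reading of a single change. At this position, one of the two matching 2-(acetylsulfanyl)ethyl chains can therefore become a 2-sulfanylethyl chain with no visible effect on the number, while the other chain and the shared core stay the same. Nothing shown here explains this result, so the reason stays unknown.

The compounds shown leave open whether a methyl group or a benzoyl group on this sulfur would also leave the number unmoved, and what happens when the second chain loses its acetyl as well. On these data alone, it also remains open whether the same step would read the same way on the core of compound 1, as this single pair speaks only for the core it shares.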